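A few compounds are considered here, and "the series" means these few. Any claim that something is new, unique, unknown or untested is made for them only; others in the source may bear on it.

Measured compounds:
compound 1 `Cc1cc(-c2ccccc2)n(/C(N)=N/S(=O)(=O)c2cc(C)c(Cl)cc2SCc2ccc(C(F)(F)F)cc2)n1`: 19000 nM
compound 2 `Cc1cc(S(=O)(=O)/N=C(\N)n2nccc2-c2ccccc2)c(SCc2ccc(C(F)(F)F)cc2)cc1Cl`: 17000 nM

In a functional assay on HeLa cells (Homo sapiens) for cytotoxicity, read by MTT assay, with a stated time of 72 h (on this read-out higher numbers stand for weaker inhibition and lower numbers for stronger inhibition), compound 1 gives 19000 nM and compound 2 gives 17000 nM. Among the measured compounds shown here, the only measured step, a 1.1-fold lower number from compound 1 to compound 2 (0.05 log units; within the scatter), sits within the scatter, so compound 2 and compound 1 cannot be ranked against each other. Compound 3 `Cc1ccc(CSc2cc(Cl)c(C)cc2S(=O)(=O)/N=C(\N)n2nccc2-c2ccccc2)cc1` differs from compound 2 by methyl in place of trifluoromethyl on an aromatic carbon. For the measured compounds named here, no measured step touches this part of the molecule, and the one step known was within the scatter, so the expected change from compound 2 to compound 3 is no change at the digits printed from compound 2 to compound 3 (within the scatter), nothing beyond the scatter. Compound 3 is therefore estimated at 17000 nM, between 6000 nM and 50000 nM.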

Compound 3, half-maximal inhibitory concentration: 17000 nM
For compound 3 middle estimate and measured number coincide at the digits printed, and the stated range covers the measured number.
By their numbers in this assay, from the lowest: compounds 2, 3 and 1 (each within the scatter of the next).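

The earlier compounds shown here said nothing about this position, and here the exchange of trifluoromethyl for methyl at the end of the benzyl group gives no change at the digits printed from compound 2 to compound 3 (within the scatter) in this assay. At this place on the ring, going from a group of four heavy atoms to one of a single heavy atom therefore leaves compound 2 and compound 3 indistinguishable. Nothing available explains this result.

On these data alone, whether an amine, a carboxylic acid or a longer chain at this position would move the number stays open. With only these three closely matched compounds, it is also unclear which part of the shared core, if any, controls cytotoxicity.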